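The source may report more compounds than this note shows. Statements on the series, on what has been measured and on what is new or still open speak of the compounds shown alone.

Compound 1 `O=C1NCCN1c1ccc(S(=O)(=O)Nc2ccccc2)cc1`: 280 nM
Compound 2 `O=C1NCCN1c1ccc(S(=O)(=O)Nc2ccc(Cl)cc2)cc1`: 220 nM

In a functional assay on HT-29 cells (Homo sapiens) for antiproliferative activity, read by sulforhodamine B assay, with a stated time of 48 h (a higher number here means a weaker inhibitor, a lower number a stronger inhibitor), compound 2 gives 220 nM, which lies within the scatter of compound 1 at 280 nM. These two compounds are the only measured reference points.

Compound 3 `Cc1ccc(C)c(NS(=O)(=O)c2ccc(N3CCNC3=O)cc2)c1` has not yet been measured. Its difference from compound 2 is 2,5-dimethylphenyl in place of 4-chlorophenyl on a sulfonamide nitrogen. In words, it has 2,5-dimethylphenyl in place of 4-chlorophenyl on a sulfonamide nitrogen.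

Among the compounds with values here, one measured step bears on this change: chloro in place of hydrogen on an aromatic carbon gave a 1.3-fold lower number from compound 1 to compound 2 (0.10 log units; within the scatter). Within the data shown here, that step also concerns the group on the sulfonamide nitrogen, but no measured compound carries 2,5-dimethylphenyl, so the evidence is indirect and the range must stay wide. Among the measured compounds shown here, with compound 2 and the step of a 1.3-fold lower number from compound 1 to compound 2 (0.10 log units; within the scatter) as the only guide, no step beyond the scatter is expected in this assay, and no direction can be favoured.

The estimated step is a 1.0-fold higher number from compound 2 to compound 3 (0.02 log units; within the scatter). For compound 3 the expected value is 230 nM, with an estimated range of 80 nM to 650 nM.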

Compound 3, half-maximal inhibitory concentration: 46 nM
Beside the measured number, compound 3's estimate is 5.0-fold (0.70 log units) above it; the whole stated range lies above it.
By their numbers in this assay, from the lowest: compound 3; then compounds 2 and 1 (each within the scatter of the next).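

In this assay, the group on the sulfonamide nitrogen turns out to be able to shift the number beyond the scatter, something the earlier replacement of hydrogen by chloro had not shown. Replacing 4-chlorophenyl with 2,5-dimethylphenyl gives a clear gain (a 4.8-fold lower number from compound 2 to compound 3 (0.68 log units; beyond the scatter)), and replacing phenyl with 2,5-dimethylphenyl gives a gain of similar size (a 6.1-fold lower number from compound 1 to compound 3 (0.78 log units; beyond the scatter)), so the result holds whichever of the two earlier groups it is set against. With only these three compounds, this is one observation for a single replacing group rather than a trend across the position, and no measurement offered here accounts for the gain.

On these data alone, whether either methyl group of 2,5-dimethylphenyl would give this step on its own remains open, as does how an ethyl, a methoxy or an amine on that ring would read. The compounds shown also leave open whether the same gain would appear in other cell lines and what changes to the shared core would do, since every comparison here rests on the group on the sulfonamide nitrogen.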